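A few compounds are considered here, and "the series" means these few. Any claim that something is new, unique, unknown or untested is made for them only; others in the source may bear on it.

Measured so far:
- compound 1, `CC(C)(C)COc1nc(C(F)(F)F)ccc1CNC(=O)Nc1cccc2[nH]ncc12`, in a functional assay for antagonist activity at transient receptor potential cation channel subfamily V member 1 (Homo sapiens); on this read-out lower numbers stand for stronger inhibition and higher numbers for weaker inhibition: 6 nM
- compound 2, `Cc1ccc(CNC(=O)Nc2cccc3[nH]ncc23)c(N2CCCCC2)n1`, in this assay: 16 nM

Compound 1 has the lowest of the two numbers seen so far; the nearest is compound 2, whose number is higher by a gap that lies beyond the usual scatter of this kind of measurement. The two compounds differ in several places at once, so the comparison shows only the two values, not what any single change does.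

The next compound, compound 3, `CC(C)(C)CCc1nc(C(F)(F)F)ccc1CNC(=O)Nc1cccc2[nH]ncc12`, keeps the shared core of compound 1 and changes one group: 3,3-dimethylbutyl in place of neopentyloxy on an aromatic carbon. Among the measured compounds shown here, nothing measured so far isolates this kind of swap. The step from compound 1 to compound 3 is expected to be small, and if anything toward a weaker number, probably within the scatter. Compound 3 is therefore expected to give about 10 nM in this assay, within a range from 3 nM to 30 nM, which corresponds to an expected step of a 1.7-fold higher number from compound 1 to compound 3 (0.22 log units; within the scatter).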

Compound 3, half-maximal inhibitory concentration: 5 nM
Estimate against measurement, compound 3: 2.0-fold (0.30 log units) above, within the range that was stated.
By their numbers in this assay, from the lowest: compounds 3 and 1 (each within the scatter of the next); then compound 2.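

Placing 3,3-dimethylbutyl where neopentyloxy stood gives a 1.2-fold lower number from compound 1 to compound 3 (0.08 log units; within the scatter) in this assay. Among the compounds shown here, this is the first comparison at this position that changes only one group, and it shows that an all-carbon chain can take the place of the oxygen-containing one while the two numbers stay within the scatter of each other. No measurement at hand explains this result.

The compounds shown leave open whether a shorter ethoxy chain, a benzyloxy group or a carboxylic acid on this aromatic carbon would give a similar number in this assay. They also leave open whether the same swap would give a step of similar size if another group, such as a chlorine atom, stood in place of the trifluoromethyl group.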